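The source may hold more compounds than are shown below. What is called first, only, known or untested is meant among the compounds shown, and "the series" means these compounds.

Measured compounds:
Compound 1, `COc1cc(C(c2ccc(O)c(OC)c2)[C@@H](C)[C@@H](C)CF)ccc1O`, 38000 nM in a functional assay on HL-60 cells (Homo sapiens) for cytotoxicity, read by WST assay, with a stated time of 48 h; on this read-out higher numbers stand for weaker inhibition and lower numbers for stronger inhibition.
Compound 2, `COC[C@@H](C(C)C)C(c1ccc(O)c(OC)c1)c1ccc(O)c(OC)c1`, 54000 nM.
Compound 3, `COC[C@@H](C)[C@@H](C)C(c1ccc(O)c(OC)c1)c1ccc(O)c(OC)c1`, 85000 nM.

Compound 3 gives the highest of the three numbers, though the step of a 1.6-fold higher number from compound 2 to compound 3 (0.20 log units; within the scatter) is within the scatter, while the step of a 2.2-fold higher number from compound 1 to compound 3 (0.35 log units; beyond the scatter) is modest and beyond it. Going by the values given here, compound 4 is `COC[C@@H](C)[C@H](C)C(c1ccc(O)c(OC)c1)c1ccc(O)c(OC)c1`. the two compounds have the same atoms and bonds and differ only in configuration as drawn: 1 of 2 stereo elements differ; a stereocentre at a saturated chain carbon is drawn S in compound 3 and R in compound 4 No measured pair differs in configuration alone, so none of the steps bears directly on this change; the chain alterations seen in a 1.4-fold higher number from compound 1 to compound 2 (0.15 log units; within the scatter) and a 1.6-fold higher number from compound 2 to compound 3 (0.20 log units; within the scatter) were small. For compound 4 no step beyond the scatter is therefore expected in this assay, in either direction. Compound 4 is estimated at 85000 nM, with a range from 40000 nM to 180000 nM, which means an expected step of no change at the digits printed from compound 3 to compound 4 (within the scatter).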

Compound 4, half-maximal inhibitory concentration: 73000 nM
Compound 4: middle estimate off by 1.2-fold (0.07 log units), on the high side; measured number inside the range.
By their numbers in this assay, from the lowest: compounds 1, 2, 4 and 3 (each within the scatter of the next, the first and the last beyond it).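

Going by these compounds alone, the one pair that isolates configuration at this saturated chain carbon reads a 1.2-fold lower number from compound 3 to compound 4 (0.07 log units; within the scatter) in this assay, so drawing it R rather than S changes nothing beyond the scatter, a comparison that rests on this: the fact that compounds 3 and 4 differ only in the configuration as drawn The step of a 1.4-fold higher number from compound 2 to compound 4 (0.13 log units; within the scatter) also stays within the scatter. Where a 2.2-fold higher number from compound 1 to compound 3 (0.35 log units; beyond the scatter) lies beyond it, a 1.9-fold higher number from compound 1 to compound 4 (0.28 log units; within the scatter) lies within it, so that single gap does not carry over to the R form.

On these data alone, it remains open whether an amine or a carboxylic acid on this chain, in place of the methoxymethyl or fluoromethyl group, would move the number beyond the scatter. As far as these compounds go, the effect of inverting the other stereocentre also remains open.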